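Hydroxy ester side chains: from compound 3 to compound 4

A few compounds are considered here, and "the series" means these few. Any claim that something is new, unique, unknown or untested is made for them only; others in the source may bear on it.

Measured in a functional assay on HeLa cells (Homo sapiens) for cytotoxicity, read by MTT assay; on this read-out higher numbers stand for weaker inhibition and lower numbers for stronger inhibition:
- compound 1 `CC(C)=CC[C@@H](OC(=O)CCO)C1=CC(=O)c2c(O)ccc(O)c2C1=O`: 67600 nM
- compound 2 `CC(C)=CC[C@@H](OC(=O)CC(O)c1ccccc1)C1=CC(=O)c2c(O)ccc(O)c2C1=O`: 44500 nM
- compound 3 `CCCC(C)(O)CC(=O)O[C@H](CC=C(C)C)C1=CC(=O)c2c(O)ccc(O)c2C1=O`: 72000 nM

Compound 3 cannot be separated from the other two compounds: a 1.1-fold higher number from compound 1 to compound 3 (0.03 log units; within the scatter) and a 1.6-fold higher number from compound 2 to compound 3 (0.21 log units; within the scatter) are both within the scatter, as is a 1.5-fold lower number from compound 1 to compound 2 (0.18 log units; within the scatter). Next is compound 4 `CCC(O)(CC)CC(=O)O[C@H](CC=C(C)C)C1=CC(=O)c2c(O)ccc(O)c2C1=O`, which has the same atoms as compound 3, joined differently: 1-ethyl-1-hydroxypropyl in place of 1-hydroxy-1-methylbutyl on a saturated chain carbon bound to a carbonyl carbon. The change sits on a saturated chain carbon bound to a carbonyl carbon, where the two steps to compound 3 also fall. Those steps swapped less similar groups, yet neither left the scatter. No step beyond the scatter is therefore expected in this assay. The expected step is a 1.1-fold lower number from compound 3 to compound 4 (0.04 log units; within the scatter). The estimate for compound 4 is 65000 nM, with an expected range of 35000 nM to 120000 nM.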

Compound 4, half-maximal inhibitory concentration: 52000 nM
The estimate for compound 4 lay 1.3-fold (0.10 log units) above the measured number; low and high end bracket the measured number.
By their numbers in this assay, from the lowest: compounds 2, 4, 1 and 3 (each within the scatter of the next).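

Rearranging the same atoms at this position, with 1-ethyl-1-hydroxypropyl in place of 1-hydroxy-1-methylbutyl, gives in this assay a step that stays unresolved (a 1.4-fold lower number from compound 3 to compound 4 (0.14 log units; within the scatter)). The new side chain also stays within the scatter of the two remaining ones (a 1.2-fold higher number from compound 2 to compound 4 (0.07 log units; within the scatter); a 1.3-fold lower number from compound 1 to compound 4 (0.11 log units; within the scatter)). Nothing available bears on any reason for this result.

From the compounds shown here alone, whether an amine or a carboxylic acid on the saturated chain carbon bound to a carbonyl carbon would leave the scatter remains open. The same applies to a longer chain.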